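Bromo for methyl on the aryl of compound 2

This account rests on a few compounds, and the source may have more. Where it says the series, first, only, none or still open, it means among the compounds named here.

Measured so far in a functional assay on A549 cells (Homo sapiens) for antiproliferative activity, read by MTT assay, with a stated time of 48 h (a lower number here means a stronger inhibitor, a higher number a weaker inhibitor), as follows:
compound 1 `Cc1ccc(-c2nnc(NC(=O)/C=C/c3ccc(C(F)(F)F)cc3)s2)cc1` gives 1.61 ug/mL
compound 2 `COc1ccc(/C=C/C(=O)Nc2nnc(-c3ccc(C)cc3)s2)cc1` gives 0.66 ug/mL
compound 3 `Cc1ccc(-c2nnc(NC(=O)/C=C/c3ccccc3)s2)cc1` gives 1.38 ug/mL

Compound 2 at 0.66 ug/mL stands lowest of the three, and both other compounds lie beyond the scatter from it. Compound 4 `COc1ccc(/C=C/C(=O)Nc2nnc(-c3ccc(Br)cc3)s2)cc1` differs from compound 2 by bromo in place of methyl on an aromatic carbon, a change from 4-methylphenyl to 4-bromophenyl. Among the compounds with values here, no measured step covers this change, since all three measured compounds carry 4-methylphenyl. Those steps exchange trifluoromethyl, methoxy and hydrogen elsewhere and serve only as a gauge of size. Both a 2.4-fold lower number from compound 1 to compound 2 (0.39 log units; beyond the scatter) and a 2.1-fold higher number from compound 2 to compound 3 (0.32 log units; beyond the scatter) are modest, while a 1.2-fold lower number from compound 1 to compound 3 (0.07 log units; within the scatter) stays within the scatter. Within the data shown here, with no bromo compound measured, no direction can be drawn. In this assay no step beyond the scatter is expected, though a modest one either way remains possible. The estimate means a 1.1-fold higher number from compound 2 to compound 4 (0.03 log units; within the scatter) as the expected step here. The estimate for compound 4 is 0.7 ug/mL and its expected range runs from 0.25 ug/mL to 1.9 ug/mL on present evidence.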

Compound 4, half-maximal inhibitory concentration: 1.04 ug/mL
The estimate for compound 4 lay 1.5-fold (0.17 log units) below the measured number, and the stated range covers the measured number.
By their numbers in this assay, from the lowest: compounds 2, 4, 3 and 1 (each within the scatter of the next, the first and the last beyond it).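

In this assay, compound 4 is the only compound shown that departs from 4-methylphenyl, so this position can now be read directly. Bromo in place of methyl on this aromatic carbon gives a 1.6-fold higher number from compound 2 to compound 4 (0.20 log units; within the scatter), so with the methoxy group of compound 2 kept, this exchange of one heavy atom for another does not move the number beyond the scatter and gives no direction. No measured property bears on this step.

Open, on these data alone, is what an amine, a carboxylic acid or a butyl chain at this position would do to the number, and whether any group here moves it beyond the scatter. Also open, as far as these compounds go, is whether bromo in place of methyl gives a step of similar size when trifluoromethyl or hydrogen stands in place of the methoxy group, as in compound 1 and compound 3.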